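The source may report more compounds than this note shows. Statements on the series, on what has been measured and on what is new or still open speak of the compounds shown alone.

Working notes on the series.

Compound 1, `CCN(CC)CCCCN/C(=N\c1ccnc2cc(Cl)ccc12)C(C)C`, is tested in an ADME assay on HepG2 cells (Homo sapiens) for cytotoxicity, read by MTT assay, with a stated time of 48 h (a lower number here means a stronger inhibitor, a higher number a weaker inhibitor), where compound 1 gives 5.01 ug/mL. Compound 2, `C/C(=N/c1ccnc2cc(Cl)ccc12)NCCCCN1CCCCC1`, gives in this assay a value of 9.81 ug/mL. On these two numbers compound 1 holds the lower one, but the gap to compound 2 lies within the usual scatter of repeated measurements, so no order between the two can be claimed.

The next compound to be measured is compound 3, `CCN(CC)CCN/C(=N\c1ccnc2cc(Cl)ccc12)C(C)C`. Against compound 1 the structural change is diethylamino in place of 2-(diethylamino)ethyl on a saturated chain carbon, two bonds along the chain from an amine nitrogen. The shared core is untouched, and the amine nitrogen at the end of the chain stays the same in kind; only the chain between it and the amidine nitrogen is shorter.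

Among the measured compounds shown here, no measured pair with this kind of change exists, so the direction is open. The step from compound 1 to compound 3 is expected to be small, with no movement beyond the scatter, as a 1.2-fold higher number from compound 1 to compound 3 (0.08 log units; within the scatter). Compound 3 is therefore estimated to give in this assay about 6 ug/mL, within a range from 3 ug/mL to 12 ug/mL.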

Compound 3, half-maximal inhibitory concentration: 12.7 ug/mL
Compound 3: middle estimate off by 2.1-fold (0.33 log units), on the low side; measured number above the stated range.
By their numbers in this assay, from the lowest: compounds 1, 2 and 3 (each within the scatter of the next, the first and the last beyond it).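

In this assay, diethylamino in place of 2-(diethylamino)ethyl, on a saturated chain carbon, two bonds along the chain from an amine nitrogen, gives a 2.5-fold higher number from compound 1 to compound 3 (0.40 log units; beyond the scatter). Among the compounds shown here, this is the first step that can be read beyond the scatter, and it is a modest one: with the diethylamino end kept, a shorter chain goes with a higher number, so this position responds to chain length. No measurement at hand bears on why the number moves.

Two shortened or lengthened forms would be needed to tell whether this holds as a trend, since one step gives a direction at a single pair only. Going by these compounds, whether a longer chain lowers the number further, and whether a primary amine at the chain end keeps the same step, stays open.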